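Replacing the Amide Substituent from Compound 3 to Compound 4

A few compounds are considered here, and "the series" means these few. Any claim that something is new, unique, unknown or untested is made for them only; others in the source may bear on it.

Of the compounds shown here, three have been measured in an ADME assay on HEK293 cells for agonist activity at metabotropic glutamate receptor 5 (Rattus norvegicus), read by fluorescence and calcium flux; on this read-out higher numbers stand for larger maximal responses and lower numbers for smaller maximal responses. Compound 1, `C[C@@H](NC(=O)c1ccc(C#Cc2ccncc2)cn1)C(C)(C)O`, gives 22.4% in this assay. Compound 2, `C[C@@H](NC(=O)c1cnc(C#Cc2cccc(F)c2)cn1)C(C)(C)O`, gives 17.2%. Compound 3, `C[C@H](NC(=O)c1ccc(C#Cc2cccc(F)c2)cn1)C(C)(C)C`, gives 20%. Compound 3 holds the second highest of the three numbers, but its number differs from that of compound 1 and from that of compound 2 by amounts that are within the usual scatter, so no order among the three can be read from these values.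

The next compound, compound 4, `CC(C)(O)CNC(=O)c1ccc(C#Cc2cccc(F)c2)cn1`, is not yet measured. It differs from compound 3 in one place: 2-hydroxy-2-methylpropyl in place of 1,2,2-trimethylpropyl on an amide-type nitrogen

Going by the values given here, no measured pair in this set shares exactly this change, so its effect is unknown. The account can only note that compound 1 and compound 2, which carry other chains on the amide-type nitrogen, give values close to that of compound 3. On that basis the step from compound 3 to compound 4 is expected to stay within the scatter, no change at the digits printed from compound 3 to compound 4 (within the scatter). Compound 4 is therefore estimated at 20%, with a range from 10% to 32%, because compound 3 gives 20% and the neighbouring compounds sit close to it.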

Compound 4, largest response reached (reported as efficacy), in percent of the reference or control that the assay uses: 20%
Estimate against measurement, compound 4: no gap at the digits printed, within the range that was stated.
By their numbers in this assay, from the lowest: compounds 2, 3, 4 and 1 (each within the scatter of the next).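

In this assay, going by these compounds alone, replacing 1,2,2-trimethylpropyl with 2-hydroxy-2-methylpropyl on an amide-type nitrogen gives no change at the digits printed from compound 3 to compound 4 (within the scatter), the first direct reading of a change at this position. The step puts a chain with a hydrogen-bond donor and a hydrogen-bond acceptor in place of one with neither, and it also removes the defined stereocentre, yet the largest response stays within the scatter, so for this pair the read-out does not separate the two chains. Nothing among the data shown explains why the response holds steady across this change.

What the compounds shown leave open is whether the same holds on the cores of compound 1 and compound 2, and how the largest response behaves with a group of another kind on this nitrogen, such as an amine, a carboxylic acid or a longer chain. Going by these compounds, the separate contributions of the hydroxyl group and of the stereocentre also remain open, as this one step changes both together.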